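The source may hold more compounds than are shown below. What is called first, only, known or untested is meant among the compounds shown, and "the series" means these compounds.

Of the compounds shown here, three of one series have so far been measured in an in vitro assay on cells for inhibition of Amine oxidase [flavin-containing] B (Homo sapiens), read by Amplex Red, with a stated time of 15 min; on this read-out higher numbers stand for weaker inhibition and lower numbers for stronger inhibition. Compound 1 `COc1ccc(/C=C/C=C/C(=O)c2ccccc2O)cc1OC` gives 14600 nM. Compound 2 `COc1ccc(/C=C/C=C/C(=O)c2cc(Cl)ccc2O)cc1` gives 153 nM. Compound 3 `O=C(/C=C/C=C/c1ccc([N+](=O)[O-])cc1)c1ccccc1O` gives 160 nM, the second highest of the three numbers, lying within the scatter of compound 2 and far below compound 1. Compound 4 `COc1ccc(/C=C/C=C/C(=O)c2ccccc2O)cc1` awaits measurement in this assay. It differs from compound 3 in one place: methoxy in place of nitro on an aromatic carbon. Going by the values given here, no single-change step between measured compounds is available, so the size of this step is uncertain; the weak number of compound 1, which also carries methoxy on that ring, is 14600 nM. A moderate rise is therefore expected, a 16-fold higher number from compound 3 to compound 4 (1.19 log units; beyond the scatter). Compound 4 is expected to give about 2500 nM, in a range from 600 nM to 10000 nM.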

Compound 4, half-maximal inhibitory concentration: 1810 nM
Compound 4: the middle estimate sits 1.4-fold (0.14 log units) above what was measured; measured number inside the range.
By their numbers in this assay, from the lowest: compounds 2 and 3 (each within the scatter of the next); then compound 4; then compound 1.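

Going by these compounds alone, on the aromatic carbon para to a large group, methoxy in place of nitro gives the first single-change reading at this position (an 11-fold higher number from compound 3 to compound 4 (1.05 log units; beyond the scatter)). Compound 4 also allows two further readings: hydrogen in place of chloro (a 12-fold higher number from compound 2 to compound 4 (1.07 log units; beyond the scatter)) and hydrogen in place of methoxy (an 8.1-fold lower number from compound 1 to compound 4 (0.91 log units; beyond the scatter)). No measurement at hand accounts for the size of these steps. The compounds shown leave open how an amine or a carboxylic acid would compare with nitro and methoxy at this position. They also leave open whether the chloro step holds with nitro in place of methoxy.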